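The compounds below may be only part of what the source reports. "The series", "measured", "known", "first", "only" and "open" are said of these compounds alone.

Measured compounds:
- compound 1 `COc1cc(/C=C/C(=O)c2cccc(-n3cc(-c4ccccc4)[nH]c3=O)c2)ccc1O`: 3770 nM
- compound 2 `COc1ccc(-c2cn(-c3cccc(C(=O)/C=C/c4cc(OC)c(OC)c(OC)c4)c3)c(=O)[nH]2)cc1`: 1280 nM

In a functional assay on HT-29 cells (Homo sapiens) for inhibition (a higher number here means a weaker inhibitor of growth, a lower number a stronger inhibitor of growth), compound 2 gives 1280 nM. In this assay compound 1 gives 3770 nM. Compound 2 stands lowest of the two numbers; its nearest neighbour is compound 1, whose number is higher by a gap beyond the usual scatter. Within the data shown here, compound 1 and compound 2 differ in more than one place, so no single step is counted between them; only their two values are known.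

Compound 3 `COc1ccc(-c2cn(-c3cccc(C(=O)/C=C/c4ccc(O)c(OC)c4)c3)c(=O)[nH]2)cc1` is not yet measured in this assay. It differs from compound 2 as follows:
4-hydroxy-3-methoxyphenyl in place of 3,4,5-trimethoxyphenyl on a double-bonded chain carbon bound to a double-bonded chain carbon
The group that enters is the same one carried by compound 1, whose 3770 nM lies above the number of compound 2. The step from compound 2 to compound 3 in this assay is therefore expected to go toward a higher number, beyond the scatter, about a 2.0-fold higher number from compound 2 to compound 3 (0.31 log units; beyond the scatter). Compound 3 is estimated at 2600 nM, with a range from 900 nM to 7500 nM.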

Compound 3, concentration for 50% growth inhibition: 3840 nM
Compound 3: the middle estimate sits 1.5-fold (0.17 log units) below what was measured; the range from low to high includes it.
By their numbers in this assay, from the lowest: compound 2; then compounds 1 and 3 (each within the scatter of the next).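

In this assay, the step from the 3,4,5-trimethoxyphenyl group to the 4-hydroxy-3-methoxyphenyl group on a double-bonded chain carbon bound to a double-bonded chain carbon can now be read directly, as a 3.0-fold higher number from compound 2 to compound 3 (0.48 log units; beyond the scatter), and it goes toward weaker growth inhibition. With 4-hydroxy-3-methoxyphenyl in place, methoxy in place of hydrogen on an aromatic carbon gives a 1.0-fold higher number from compound 1 to compound 3 (0.01 log units; within the scatter), so this change does not separate the two compounds. Nothing at hand bears on the cause of either step.

The compounds shown leave open whether the hydroxy group or the count of methoxy groups carries the first step. From the compounds shown here alone, how an amine or a carboxylic acid in place of that hydroxy group would read also remains open.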